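The source may report more compounds than this note shows. Statements on the series, on what has been measured and on what is new or still open speak of the compounds shown alone.

Working notes on the series. Three analogues share one core and differ only at one aromatic carbon: compound 1 `Cc1ccc2[nH]c(=O)c(CN(Cc3ccc(N(C)C)cc3)Cc3ccc(C(C)(C)C)cc3)cc2c1` carries methyl there, compound 2 `COc1ccc2[nH]c(=O)c(CN(Cc3ccc(N(C)C)cc3)Cc3ccc(C(C)(C)C)cc3)cc2c1` methoxy, compound 3 `CN(C)c1ccc(CN(Cc2ccc(C(C)(C)C)cc2)Cc2cc3cc(Cl)ccc3[nH]c2=O)cc1` chloro. In a toxicity assay on MDCK cells (Canis lupus familiaris) for cytotoxicity, read by crystal violet staining, with a stated time of 48 h (on this read-out lower numbers stand for higher toxicity in this test and higher numbers for lower toxicity in this test), compound 2 gives 8500 nM. For compound 1 the value in this assay is a limit of the assay, > 5000 nM. For compound 3 the value in this assay is likewise a limit, > 10000 nM. Compound 3 therefore stands only at a limit, and one further value of the three is also a limit. The step of an at least 1.1-fold higher number from compound 2 to compound 3 (0.07 log units; that floor lies within the scatter) is readable only as a floor. The steps a step that the limit leaves unreadable from compound 1 to compound 2 and a step that the two limits leave unreadable from compound 1 to compound 3 cannot be sized because the limit of > 5000 nM in this assay, at which 1 of the 3 values shown sits, and the limit of > 10000 nM in this assay, at which 1 of the 3 values shown sits, cap them.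

Compound 4 `CN(C)c1ccc(CN(Cc2ccc(C(C)(C)C)cc2)Cc2cc3cc(Br)ccc3[nH]c2=O)cc1` differs from compound 3 by bromo in place of chloro on an aromatic carbon. Among the measured compounds shown here, no measured step exchanges one halogen for another; the only step that bears on it, an at least 1.1-fold higher number from compound 2 to compound 3 (0.07 log units; that floor lies within the scatter), has a floor within the scatter. The step that the limit leaves unreadable from compound 3 to compound 4 is therefore expected to stay within the scatter, with a fair chance that this assay again reports only a limit. Compound 4 is expected to give 12000 nM in this assay, in the range 5000 nM to 30000 nM.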

Compound 4, half-maximal cytotoxic concentration: > 10000 nM
Compound 4: only a limit was reported (the forecaster's own chance of this, stated with the estimate: 70%); the middle value is on the limit's open side.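

With bromo on this aromatic carbon, compound 4 again gives only a limit of the assay in this assay, > 10000 nM. Among the compounds shown here, the only step that can be read is an at least 1.1-fold higher number from compound 2 to compound 4 (0.07 log units; that floor lies within the scatter), the same floor as an at least 1.1-fold higher number from compound 2 to compound 3 (0.07 log units; that floor lies within the scatter), so neither halogen in place of methoxy shows a change that can be told from the scatter. The steps for bromo in place of chloro and bromo in place of methyl cannot be read, because limits stand at their ends: the limit of > 10000 nM in this assay, at which 2 of the 4 values shown sit; the limit of > 5000 nM in this assay, at which 1 of the 4 values shown sits.

Going by these compounds, the order among methyl, chloro and bromo at this position in this assay remains open, since none of the three has a number. Also open, on these data alone, is whether an amine or a carboxylic acid on this aromatic carbon would give a measured value rather than a limit, and whether such a value would differ from that of compound 2 by more than the scatter.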